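The source may report more compounds than this note shows. Statements on the series, on what has been measured and on what is new or still open speak of the compounds shown alone.

Measured compounds:
compound 1, `c1ccc(-c2ccc3c(NCCCNCc4ccco4)ccnc3c2)cc1`: 32000 nM
compound 2, `COc1cccc(CNCCCNc2ccnc3cc(-c4ccc(C(F)(F)F)cc4)ccc23)c1O`: 32000 nM

The study concerns solubility, measured in a physicochemical assay for solubility, with a stated time of 18 h, at pH 7.4; on this read-out higher numbers stand for higher solubility and lower numbers for lower solubility. Of the compounds shown here, two have values so far. In this assay compound 1 gives 32000 nM. Compound 2, which carries a different aryl group on the shared core and a methoxy and hydroxyl on the benzylic ring, gives 32000 nM in this assay; its value is level with that of compound 1 at the digits shown, so the two sit within the scatter of each other and no order can be read between them.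

The next compound is compound 3, `Fc1ccc(Cc2ccc3c(NCCCNCc4ccco4)ccnc3c2)c(Cl)c1`. Compared with compound 1 it carries 2-chloro-4-fluorobenzyl in place of phenyl on an aromatic carbon. Among the measured compounds shown here, no measured pair in this set isolates a change of this kind, so the size of the step is open. Given that compounds 1 and 2 share the same value, the expectation for compound 3 is a modest downward step in this assay, a 2.1-fold lower number from compound 1 to compound 3 (0.33 log units; beyond the scatter), though a result within the scatter would not surprise. The solubility of compound 3 is therefore estimated at 15000 nM, with a range from 5000 nM to 32000 nM.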

Compound 3, solubility: 4200 nM
Beside the measured number, compound 3's estimate is 3.6-fold (0.55 log units) above it; the whole stated range lies above it.
By their numbers in this assay, from the lowest: compound 3; then compounds 1 and 2 (each within the scatter of the next).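

Setting 2-chloro-4-fluorobenzyl in place of phenyl on this aromatic carbon gives, in this assay, a 7.6-fold lower number from compound 1 to compound 3 (0.88 log units; beyond the scatter), and this is the only step in the set so far that isolates a single change. It shows that the number in this assay is sensitive to the group held at this position, even though the swap keeps one six-membered aromatic ring of carbon only, adds no hydrogen-bond donors or acceptors and brings no net charge, while the group grows from 6 heavy atoms to 9. No measurement here bears on why the number falls.

The single change brings in a carbon link, a chlorine and a fluorine at once, so the compounds shown do not tell which of these carries the step, and a plain benzyl or a 4-fluorophenyl group would be needed to separate them. Also open, from the compounds shown here alone, is whether an amine or a carboxylic acid on the aryl group at this position would move the number the other way, and compound 2 differs from compound 3 in more than one place, so it cannot settle either question.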